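The source may hold more compounds than are shown below. What is called first, only, known or untested is meant among the compounds shown, and "the series" means these compounds.

Measured so far in a functional assay on Bel-7402 cells (Homo sapiens) for inhibition, read by MTT assay, with a stated time of 24 h, tested at 10 ug/mL (on this read-out lower numbers stand for less inhibition of growth and higher numbers for more inhibition of growth at the one concentration tested), on the shared core:
- compound 1 `O=C(CCCCC(S)CCS)Nc1ccccc1` gives 3.72%
- compound 2 `O=C(CCCCC(S)CCS)Nc1ccc(F)cc1` gives 6.14%

Among the measured compounds shown here, compound 2 at 6.14% stands within the scatter of compound 1, the only other measured compound. Compound 3 `O=C(CCCCC(S)CCS)Nc1ccc(OC(F)(F)F)cc1` carries trifluoromethoxy in place of fluoro on an aromatic carbon and has not been measured. For the measured compounds named here, the one measured step that bears on this change is a number 2.4 percentage points higher from compound 1 to compound 2 (within the scatter) and it gives no sign of a step beyond the scatter in this assay for this change. The estimated step is a number 1.9 percentage points higher from compound 2 to compound 3 (within the scatter) and no shift beyond the scatter is expected. Compound 3 is estimated at 8% with an expected range from 0% to 20% in this read-out.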

Compound 3, percent growth inhibition at one concentration: 14.2%
Compound 3: the middle estimate sits 6.2 percentage points below what was measured; measured number inside the range.
By their numbers in this assay, from the lowest: compounds 1, 2 and 3 (each within the scatter of the next, the first and the last beyond it).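

In this assay, among the compounds shown here, the aromatic carbon para to a large group gives the first step beyond the scatter: trifluoromethoxy in place of hydrogen gives a number 10.5 percentage points higher from compound 1 to compound 3 (beyond the scatter) on the shared core. Fluoro and trifluoromethoxy remain unseparated at this position, with a number 8.1 percentage points higher from compound 2 to compound 3 (within the scatter) and so no difference beyond the scatter. No measurement at hand accounts for the modest step. Open, as far as these compounds go, is how an amine, a carboxylic acid or a longer alkoxy chain at this position would read, and whether any group here gives more than modest growth inhibition at the one concentration tested.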